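The source may report more compounds than this note shows. Statements on the series, on what has been measured and on what is new or still open speak of the compounds shown alone.

In an assay on Sf9 cells for inhibition of inhibitor of nuclear factor kappa-B kinase subunit epsilon (Homo sapiens), read by ADP-Glo, with a stated time of 60 min (on this read-out higher numbers stand for weaker inhibition and lower numbers for stronger inhibition), compound 1 `Cc1[nH]nc(N)c1-c1cccc(OC(F)(F)F)c1` gives > 100000 nM, which is a limit of the assay and not a number. Compound 2 `Cc1[nH]nc(N)c1-c1ccc(OCc2ccccc2)cc1` gives in this assay 15400 nM. Compound 3 `Cc1nn(C(=O)C2CCC2)c(N)c1-c1ccc(Cl)c(Cl)c1` gives in this assay > 100000 nM, again a limit rather than a measured number. Compound 3 thus stands at the limit of > 100000 nM in this assay, at which 2 of the 3 values shown sit, so its position relative to the other compounds is not fixed. Compound 4 `Cc1nn(C(=O)c2ccncc2)c(N)c1-c1ccc(Cl)c(Cl)c1` differs from compound 3 by pyridin-4-yl in place of cyclobutyl on a carbonyl carbon. No measured step covers this change, and the shown compounds give no ground to expect a move beyond the scatter in either direction, though a modest shift toward stronger inhibition is not excluded. Compound 4 is therefore estimated at 60000 nM, with a range from 15000 nM to 200000 nM. The step this estimate implies, an at least 1.6-fold lower number from compound 3 to compound 4 (0.22 log units; that floor lies within the scatter), is expected to lie near the edge of the scatter.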

Compound 4, half-maximal inhibitory concentration: > 100000 nM
Compound 4: no number, only a limit; the forecaster's own chance of this, stated with the estimate: 55%; at least 1.6-fold (0.22 log units) between middle value and limit.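

In this assay, for the compounds shown here, compound 3 and compound 4 both give only a limit of the assay, so no step between them can be read. The compounds shown leave open whether pyridin-4-yl in place of cyclobutyl on a carbonyl carbon changes inhibition at all.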